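The source may report more compounds than this note shows. Statements on the series, on what has been measured and on what is new or still open speak of the compounds shown alone.

Measured so far:
compound 1 `O=C(NO)c1ccc(N(Cc2ccc(C3CCCCC3)cc2)C(=O)[C@H]2CCN2S(=O)(=O)c2c(F)c(F)c(F)c(F)c2F)cc1` — 5000 nM
compound 2 `CONC(=O)c1ccc(N(Cc2ccc(C3CCCCC3)cn2)C(=O)[C@H]2CCN2S(=O)(=O)c2c(F)c(F)c(F)c(F)c2F)c(F)c1` — "not determined" (no result reported)

In a functional assay on MDA-MB-231 cells (Homo sapiens) for antiproliferative activity, with a stated time of 72 h (a lower number here means that less compound is needed, a higher number that more compound is needed for the effect), compound 1 gives 5000 nM. Among the compounds with values here, compound 2 has no single number in this assay, so no measured step leads out of it. Compound 3 `O=C1NCc2cc(N(Cc3ccc(C4CCCCC4)cn3)C(=O)[C@H]3CCN3S(=O)(=O)c3c(F)c(F)c(F)c(F)c3F)c(F)cc21` differs from compound 2 by a group of 11 heavy atoms (8 carbon, 1 nitrogen, 1 oxygen, 1 fluorine; one five-membered non-aromatic ring with 1 hetero atom, one six-membered aromatic ring of carbon only) in place of a group of 12 heavy atoms (8 carbon, 1 nitrogen, 2 oxygen, 1 fluorine; one six-membered aromatic ring of carbon only), on an amide-type nitrogen. Within the data shown here, with no measured pair to set a scale, the step into compound 3 in this assay is uncertain; a modest loss, around the scatter or somewhat beyond it, is the direction expected. Compound 3 is estimated to give about 10000 nM, with a range from 2000 nM to 50000 nM.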

Compound 3, half-maximal effective concentration: 2000 nM
Compound 3: the middle estimate sits 5.0-fold (0.70 log units) above what was measured; measured number inside the range.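

In this assay, within the data shown here, compound 2 has no single number, so no step to compound 3 can be read. On these data alone, whether replacing the 2-fluoro-4-(methoxycarbamoyl)phenyl group changes activity stays open, and no supporting evidence bears on this result.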